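A few compounds are considered here, and "the series" means these few. Any claim that something is new, unique, unknown or untested is made for them only; others in the source may bear on it.

Compound 1 `CN(C)c1ccc(C(=O)Nc2cccc(NC(=O)COc3ccc4c(c3)NC(=O)CC4)c2)cc1`: in an assay on isolated protein for inhibition of Rho-associated protein kinase 2 (Homo sapiens), read by scintillation counting, radiometric assay and 33P incorporation, with a stated time of 40 min, in the presence of a further agent that is not named here (on this read-out higher numbers stand for weaker inhibition and lower numbers for stronger inhibition), compound 1 gives 3140 nM.
Compound 2 `CN(C)c1ccc(C(=O)Nc2cccc(NC(=O)COc3ccc4occc(=O)c4c3)c2)cc1`: in this assay compound 2 reaches only > 10000 nM, which is a limit of the assay rather than a number.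
Compound 3 `O=C(COc1ccc2c(=O)ccoc2c1)Nc1cccc(NC(=O)c2ccccc2)c1`: in this assay compound 3 gives 16 nM.

Among these, compound 3 holds the lowest number; the only other number, from compound 1, lies far higher. Going by the values given here, the single measured step, an at least 3.1-fold higher number from compound 1 to compound 2 (0.50 log units; beyond the scatter), exchanges the ring system on an oxygen on a saturated carbon, and compound 2 ends at the limit (the limit of > 10000 nM in this assay, at which 1 of the 3 values shown sits). Compound 4 `O=C(COc1ccc2c(=O)ccoc2c1)Nc1cccc(NC(=O)c2ccc(F)cc2)c1` differs from compound 3 by fluoro in place of hydrogen on an aromatic carbon of the benzamido group. Among the compounds with values here, no measured step touches that group, so nothing here predicts the change directly; the step of no change at the digits printed from compound 3 to compound 4 (within the scatter) is expected to stay within the scatter. Compound 4 is estimated at 16 nM, between 6 nM and 45 nM.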

Compound 4, half-maximal inhibitory concentration: 54 nM
For compound 4 the middle estimate is 3.4-fold (0.53 log units) below the measured one; measured number outside the range, above it.
By their numbers in this assay, from the lowest: compound 3; then compound 4; then compound 1. At a limit, above all of these: compound 2.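

Going by these compounds alone, this is the first measured change on the benzamido group, and it shows that this position is not indifferent: fluoro in place of hydrogen, para to a large group, gives a 3.4-fold higher number from compound 3 to compound 4 (0.53 log units; beyond the scatter), meaning weaker inhibition. A single added atom is thus enough to move the number beyond the scatter. Nothing measured here explains why the number rises. Still open, as far as these compounds go, is whether a different group at this place, such as a chloro, a methoxy, an amine or a carboxylic acid, would also weaken inhibition or instead strengthen it.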